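Swapping a para group on a cinnamide benzophenone

The compounds below may be only part of what the source reports. "The series", "measured", "known", "first", "only" and "open" are said of these compounds alone.

Of the compounds shown here, two have been measured for how strongly they kill colon cancer cells, in a functional assay on COLO 205 cells (Homo sapiens) for cytotoxicity, read by MTT assay, with a stated time of 72 h; a higher number here means a weaker inhibitor, a lower number a stronger inhibitor. Compound 1 `C#CCOc1cccc(/C=C/C(=O)Nc2cc(C(=O)c3cc(OC)c(OC)c(OC)c3)ccc2OC)c1` gives 13400 nM. Compound 2 `COc1ccc(C(=O)c2cc(OC)c(OC)c(OC)c2)cc1NC(=O)/C=C/c1ccc(C(F)(F)F)cc1` gives 2600 nM. Among the compounds with values here, the one comparison available, a 5.2-fold lower number from compound 1 to compound 2 (0.71 log units; beyond the scatter), exchanges the whole aryl group on the chain, so compound 2 stands with the lowest number of the two, and its only neighbour is compound 1.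

Compound 3 `COc1ccc(C(=O)c2cc(OC)c(OC)c(OC)c2)cc1NC(=O)/C=C/c1ccc([N+](=O)[O-])cc1` is not yet measured. It differs from compound 2 by nitro in place of trifluoromethyl on an aromatic carbon. Within the data shown here, no measured step exchanges one para group for another on this ring; the single step from compound 1 to compound 2 changed the ring substitution pattern as a whole and so bears on this change only loosely. With that thin basis, the expected step in this assay for compound 3 is a 1.0-fold lower number from compound 2 to compound 3 (0.02 log units; within the scatter), a change that need not exceed the scatter in either direction. Compound 3 is therefore estimated at 2500 nM, within a range of 800 nM to 8000 nM.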

Compound 3, half-maximal inhibitory concentration: 11400 nM
Estimate against measurement, compound 3: 4.6-fold (0.66 log units) below; the whole stated range lies below it.
By their numbers in this assay, from the lowest: compound 2; then compounds 3 and 1 (each within the scatter of the next).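

Within the data shown here, this is the first comparison in which only the group on an aromatic carbon, para to a large group, changes, and in this assay the choice of group matters: nitro in place of trifluoromethyl gives a 4.4-fold higher number from compound 2 to compound 3 (0.64 log units; beyond the scatter), so this position does not treat the two groups alike. The other new step, a 1.2-fold lower number from compound 1 to compound 3 (0.07 log units; within the scatter), places 4-nitrophenyl level with 3-(propargyloxy)phenyl, so among these three compounds, only compound 2 stands apart, and a group para to a large group does not by itself bring the lower number, as compound 3 shows. Nothing measured here explains why trifluoromethyl and nitro part ways, even though the counted difference between them is small.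

The compounds shown leave open how an amine, a chlorine or a carboxylic acid on that same aromatic carbon would compare with trifluoromethyl and nitro, since two groups at one position cannot show a trend. They also cannot tell whether compound 2 marks a real preference for trifluoromethyl or is simply one point in a wider spread of values.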